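The source may hold more compounds than are shown below. What is called first, only, known or untested is meant among the compounds shown, and "the series" means these compounds.

Three compounds share one core and differ only in the amino acid-like side chain attached through the amide. Compound 1 `CC(C)C[C@@H](N)C(=O)Nc1cc2cc[nH]c(=O)c2cc1Cl` carries an isobutyl group on the carbon that bears the amine; compound 2 `O=C(Nc1cc2cc[nH]c(=O)c2cc1Cl)[C@H]1CCCN1` closes that carbon into a pyrrolidine; compound 3 `N[C@H](C(=O)Nc1cc2cc[nH]c(=O)c2cc1Cl)C1CCCCC1` carries a cyclohexyl group there. In an assay on isolated protein for inhibition of Rho-associated protein kinase 2 (Homo sapiens) (a higher number here means a weaker inhibitor, a lower number a stronger inhibitor), compound 1 gives 19 nM, compound 2 gives 130 nM, and compound 3 gives 20 nM. Compound 3 thus stands second highest of the three numbers, within the scatter of compound 1 and well apart from compound 2. For the measured compounds named here, the only single-point step measured is a 6.8-fold higher number from compound 1 to compound 2 (0.84 log units; beyond the scatter), which shows that reshaping this side chain can move the number modestly.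

Compound 4 `CC(C)C[C@H](N)C(=O)Nc1cc2cc[nH]c(=O)c2cc1Cl` is the next compound. It differs from compound 3 by isobutyl in place of cyclohexyl on a saturated chain carbon bound to an amine nitrogen and a carbonyl carbon. Compound 1 carries the same isobutyl group on that carbon, and its value, 19 nM, sits within the scatter of compound 3, so the swap of cyclohexyl for isobutyl by itself is not expected to move the number beyond the scatter. Compound 4 is therefore expected to give 35 nM, with a plausible range from 12 nM to 150 nM, which amounts to an estimated step of a 1.8-fold higher number from compound 3 to compound 4 (0.24 log units; within the scatter).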

Compound 4, half-maximal inhibitory concentration: 340 nM
The estimate for compound 4 lay 9.7-fold (0.99 log units) below the measured number; measured number above the stated range.
By their numbers in this assay, from the lowest: compounds 1 and 3 (each within the scatter of the next); then compound 2; then compound 4.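

The position turns out to be sensitive to more than the name of the group placed on it. In this assay the largest gap so far, an 18-fold higher number from compound 1 to compound 4 (1.25 log units; beyond the scatter), comes with no change of atoms at all, so what separates this pair can only lie in the arrangement in space at the saturated chain carbon, which is drawn R in one and S in the other: the fact that compounds 1 and 4 differ only in the configuration as drawn. The isobutyl group therefore cannot be judged apart from the configuration of the carbon that carries it, and the swap of cyclohexyl for isobutyl proves far from silent, with a 17-fold higher number from compound 3 to compound 4 (1.23 log units; beyond the scatter) and with a 2.6-fold higher number from compound 2 to compound 4 (0.42 log units; beyond the scatter), which places the pyrrolidine ahead of this isobutyl form as well.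

The compounds shown leave open whether the opposite drawn configuration would cost as much with cyclohexyl or pyrrolidin-2-yl as it does with isobutyl. They also leave open how a smaller methyl group, a phenyl ring or a longer chain on the same carbon would fare in either configuration.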